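The source may report more compounds than this note shows. Statements on the series, on what has been measured and on what is new or still open speak of the compounds shown alone.

In an assay on isolated protein for inhibition of ubiquitin carboxyl-terminal hydrolase 7 (Homo sapiens), with stated times of 30 min and 2 h (a lower number here means a stronger inhibitor, a higher number a weaker inhibitor), three compounds have been measured:

Compound 1 `Cn1nc2c(=O)n(CC3(O)CCN(Cc4ccc(-c5ccco5)cc4Cl)CC3)cnc2c1-c1ccc(CNCCO)cc1`: 8.2 nM
Compound 2 `Cn1nc2c(=O)n(CC3(O)CCN(Cc4ccc(-c5ccc[nH]5)cc4Cl)CC3)cnc2c1-c1ccc(CN)cc1`: 193 nM
Compound 3 `Cn1nc2c(=O)n(CC3(O)CCN(Cc4ccc(-c5ncco5)cc4Cl)CC3)cnc2c1-c1ccc(CN)cc1`: 1120 nM

Compound 1 gives the lowest number of the three. Compound 2 is the nearest to it, and compound 3 lies furthest away; both gaps are beyond the usual scatter. Going by the values given here, the only single-point comparison among the measured compounds is a 5.8-fold higher number from compound 2 to compound 3 (0.76 log units; beyond the scatter), which concerns the ring on the chlorinated aryl group and not the side chain on the other aromatic ring.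

Compound 4 `Cn1nc2c(=O)n(CC3(O)CCN(Cc4ccc(-c5ccco5)cc4Cl)CC3)cnc2c1-c1ccc(CNC=O)cc1` is derived from compound 1 by one change: formyl in place of 2-hydroxyethyl on an amine nitrogen. Among the compounds with values here, compounds 1 and 2 differ from each other in two places, so their values do not isolate the contribution of the amine side chain, and no measured step touches the position altered in compound 4. Within the data shown here, there is therefore no direct precedent for this replacement in this set. The change is small in size, and in the absence of a bearing step the expectation for compound 4 is a step of modest size, most likely toward a somewhat higher number, expressed as a 3.0-fold higher number from compound 1 to compound 4 (0.48 log units; beyond the scatter). Compound 4 is thus expected to give about 25 nM, with a range from 6 nM to 110 nM in this assay.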

Compound 4, half-maximal inhibitory concentration: 20.9 nM
Compound 4: the middle estimate sits 1.2-fold (0.08 log units) above what was measured; the range from low to high includes it.
By their numbers in this assay, from the lowest: compound 1; then compound 4; then compound 2; then compound 3.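

In this assay, going by these compounds alone, the substituent on the amine nitrogen now has a measured step of its own, with formyl in place of 2-hydroxyethyl (a 2.5-fold higher number from compound 1 to compound 4 (0.41 log units; beyond the scatter)), a change the earlier compounds could not isolate. The step is modest and it spans a real change in the group: 2-hydroxyethyl counts 1 hydrogen-bond donor and formyl counts 0, while each counts 1 hydrogen-bond acceptor, and formyl also has one heavy atom fewer and a double bond that 2-hydroxyethyl lacks. Compound 4 therefore stays close to compound 1 despite this replacement, but nothing measured on these compounds explains why the number rises.

On these data alone, what the nitrogen would give with no substituent on it remains open, since compound 2 and compound 3 carry the unsubstituted amine but also differ from compound 1 in the ring on the chlorinated aryl group. Also open, as far as these compounds go, is whether the step reflects the loss of the hydroxyl or the arrival of the carbonyl, which an ethyl group, an acetyl group or a longer chain such as 3-hydroxypropyl on the same nitrogen would help to separate.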